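The compounds below may be only part of what the source reports. "The series", "measured", "known", "first", "only" and "open" are said of these compounds alone.

Measured in a functional assay on RXF 393 cells (Homo sapiens) for inhibition, read by sulforhodamine B assay, with a stated time of 48 h; a higher number here means a weaker inhibitor of growth, a lower number a stronger inhibitor of growth:
Compound 1 `O=C(Nc1cccc(-n2cc(-c3ccncc3)c(-c3ccc(Cl)c(O)c3)n2)c1)Nc1cccc(C(F)(F)F)c1` gives 3020 nM.
Compound 2 `COc1cc(-c2nn(-c3cccc(NC(=O)Nc4cc(C(F)(F)F)cc(C(F)(F)F)c4)c3)cc2-c2ccncc2)ccc1Cl` gives 869 nM.
Compound 3 `COc1cc(-c2nn(-c3cccc(NC(=O)c4cccc(C(F)(F)F)c4)c3)cc2-c2ccncc2)ccc1Cl` gives 811 nM.

Compound 3 has the lowest of these three numbers, but compound 2 sits within the usual scatter of it, so the two cannot be ranked; only compound 1 stands clearly higher, beyond the scatter. Compound 4 `COc1cc(-c2nn(-c3cccc(NC(=O)Nc4ccc(Cl)c(Cl)c4)c3)cc2-c2ccncc2)ccc1Cl` is reached from compound 3 by a single change: (3,4-dichlorophenyl)amino in place of 3-(trifluoromethyl)phenyl on a carbonyl carbon. Within the data shown here, no measured pair shows this exact change, and the three numbers at hand give no sign that such a change moves the result far. In this assay the step is therefore expected to be small, in either direction, and likely not beyond the scatter. For compound 4 the estimate is 1000 nM, within a range of 400 nM to 2500 nM. The expected step is a 1.2-fold higher number from compound 3 to compound 4 (0.09 log units; within the scatter).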

Compound 4, concentration for 50% growth inhibition: 859 nM
Compound 4: middle estimate off by 1.2-fold (0.07 log units), on the high side, and the stated range covers the measured number.
By their numbers in this assay, from the lowest: compounds 3, 4 and 2 (each within the scatter of the next); then compound 1.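

In this assay, putting (3,4-dichlorophenyl)amino in place of 3-(trifluoromethyl)phenyl on the carbonyl carbon gives a 1.1-fold higher number from compound 3 to compound 4 (0.02 log units; within the scatter) and so leaves no readable difference. This exchange brings in a hydrogen-bond donor and swaps the ring's substituents, yet the two compounds cannot be told apart here. No measurement at hand accounts for this result. The compounds shown leave open what happens when the aromatic ring at this place gives way to a longer chain or to a group carrying a carboxylic acid.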